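Biaryl-to-acrylate replacement in an anilide cinnamate series

This account rests on a few compounds, and the source may have more. Where it says the series, first, only, none or still open, it means among the compounds named here.

Measured so far:
compound 1, `CCOc1cccc(-c2ccc(CN(C(=O)C3CCCCC3)c3cccc(/C=C/C(=O)OC)c3)cc2)c1`: 147 nM
compound 2, `COC(=O)/C=C/c1cccc(N(Cc2ccc(-c3cccc(C)c3)cc2)C(=O)C2CCCCC2)c1`: 109 nM
compound 3, `COC(=O)/C=C/c1cccc(N(Cc2ccc(-c3cccc(C)c3)cc2)C(=O)C(C)C)c1`: 163 nM

In an assay on isolated protein with Bile acid receptor (Homo sapiens) as the target (on this read-out higher numbers stand for an effect only at larger amounts of compound and lower numbers for an effect already at smaller amounts), compound 2 carries the low number of the three, but this placing means little: a 1.3-fold lower number from compound 1 to compound 2 (0.13 log units; within the scatter) and a 1.5-fold higher number from compound 2 to compound 3 (0.17 log units; within the scatter) both sit within the scatter, so the three compounds are not separated on this read-out.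

Compound 4, `COC(=O)/C=C/c1ccc(CN(C(=O)C2CCCCC2)c2cccc(/C=C/C(=O)OC)c2)cc1`, differs from compound 2 by one change: 2-(methoxycarbonyl)ethenyl in place of 3-methylphenyl on an aromatic carbon. Neither measured step bears on it. The step from compound 1 to compound 2 alters a small group on the distal ring, and the step from compound 2 to compound 3 alters the acyl group; both leave the biaryl intact. Among the compounds with values here, no measured pair tests removal of the 3-methylphenyl ring itself, so the expectation for this assay rests on the size of the change alone. A second 2-(methoxycarbonyl)ethenyl group in place of an aromatic ring is a substantial change, and a shift to a higher number is expected, with wide uncertainty, as a 3.7-fold higher number from compound 2 to compound 4 (0.56 log units; beyond the scatter). Compound 4 is therefore estimated at 400 nM, within a range of 110 nM to 1500 nM.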

Compound 4, half-maximal effective concentration: > 1000 nM
Compound 4 was reported as a limit (the forecaster's own chance of this, stated with the estimate: 10%); middle value at least 2.5-fold (0.39 log units) away from the limit.
By their numbers in this assay, from the lowest: compounds 2, 1 and 3 (each within the scatter of the next). At a limit, above all of these: compound 4.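

In this assay compound 4 gives > 1000 nM, which is a limit of the assay and not a number. On the aromatic carbon para to a large group, 2-(methoxycarbonyl)ethenyl in place of 3-methylphenyl gives an at least 9.1-fold higher number from compound 2 to compound 4 (0.96 log units; beyond the scatter), and in place of 3-ethoxyphenyl it gives an at least 6.8-fold higher number from compound 1 to compound 4 (0.83 log units; beyond the scatter). Within the data shown here, these are the first steps beyond the scatter, whereas methyl in place of ethoxy and isopropyl in place of cyclohexyl both stayed within it, so this position responds to replacement of the whole aryl group far more than to either of those smaller edits.

Compound 4 is a single replacement, so loss of the aromatic ring and entry of the ester cannot be told apart. As far as these compounds go, what a pyridine ring at this position, or a carboxylic acid on the ethenyl chain, would give remains open.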